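Carbamate variation in a selenocyanate series

The source may report more compounds than this note shows. Statements on the series, on what has been measured and on what is new or still open speak of the compounds shown alone.

Compound 1 `CCCOC(=O)Nc1ccc([Se]C#N)cc1` and compound 2 `CCOC(=O)Nc1ccc([Se]C#N)cc1` share one core and differ in a single place. In an ADME assay on 184B5 cells (Homo sapiens) for cytotoxicity, read by MTT assay, with a stated time of 72 h (a lower number here means a stronger inhibitor of growth, a higher number a weaker inhibitor of growth), compound 1 gives 9100 nM, and compound 2 gives 18600 nM, so compound 2 holds the highest of the two numbers. Among the compounds with values here, the only measured step is a 2.0-fold higher number from compound 1 to compound 2 (0.31 log units; beyond the scatter). Compound 3 `N#C[Se]c1ccc(NC(=O)Oc2ccccc2)cc1` carries the change (phenyl in place of ethyl on an oxygen next to a carbonyl group). That single step bears on it only loosely, since it concerns a chain and not a ring; still, a modest move to a lower number is expected for compound 3, about a 1.9-fold lower number from compound 2 to compound 3 (0.27 log units; within the scatter). Compound 3 is expected at 10000 nM, within 3500 nM to 30000 nM.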

Compound 3, concentration for total growth inhibition: 22700 nM
For compound 3 the middle estimate is 2.3-fold (0.36 log units) below the measured one; the range from low to high includes it.
By their numbers in this assay, from the lowest: compound 1; then compounds 2 and 3 (each within the scatter of the next).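

At this position, on an oxygen next to a carbonyl group, a ring is tolerated in this assay: phenyl in place of ethyl gives a 1.2-fold higher number from compound 2 to compound 3 (0.09 log units; within the scatter) and so does not separate from the ethyl carbamate. Phenyl in place of propyl gives a 2.5-fold higher number from compound 1 to compound 3 (0.40 log units; beyond the scatter) and so leaves propyl as the only group here set apart from phenyl. No measured evidence accounts for this pattern. On these data alone, whether a longer chain such as butyl would extend the step from ethyl to propyl stays open. So does the effect of a benzyl group or of a substituted phenyl ring.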